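The source may hold more compounds than are shown below. What is called first, only, known or untested is meant among the compounds shown, and "the series" means these compounds.

Measured compounds and their values:
- compound 1 `COc1cc2c(cc1OC)C(CC(=O)NC1CCCCC1)CC2`: 44.7%
- compound 2 `COc1cc2c(cc1OC)C(CC(=O)N1CCCC1)CC2`: 19.2%
- compound 3 `COc1cc2c(cc1OC)C(CC(=O)N1CCNCC1)CC2`: 68.8%

All three share one core and differ only in the group attached to the carbonyl carbon of the amide. In a functional assay on the whole organism (strain Swiss albino) for inhibition, with Mus musculus as the target, in the writhing test, with stated times of 60 min and 15 min, at a dose of 100 mg/kg by the oral route (on this read-out lower numbers stand for less inhibition and higher numbers for more inhibition at the one dose given (going by the name of the read-out)), compound 1 gives 44.7%, while compound 2 gives 19.2% and compound 3 gives 68.8%. Compound 3 therefore stands highest of the three: the step of a number 24.1 percentage points higher from compound 1 to compound 3 (beyond the scatter) and the step of a number 49.6 percentage points higher from compound 2 to compound 3 (beyond the scatter) are both beyond the scatter, so its lead over each of the others is real.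

Compound 4 `COc1cc2c(cc1OC)C(CC(=O)N1CCOCC1)CC2` has not been measured. It differs from compound 3 in one place: morpholin-4-yl in place of piperazin-1-yl on a carbonyl carbon. The measured steps that bear on this are those that also swap the group on the carbonyl carbon: a number 25.5 percentage points lower from compound 1 to compound 2 (beyond the scatter), a number 24.1 percentage points higher from compound 1 to compound 3 (beyond the scatter) and a number 49.6 percentage points higher from compound 2 to compound 3 (beyond the scatter). They show that exchanging this one group shifts the read-out by modest to large amounts in either direction. Among the measured compounds shown here, no measured compound carries a morpholin-4-yl group, so the direction for compound 4 is uncertain; since compound 3 is already the top value, a drop is expected, a number 28.8 percentage points lower from compound 3 to compound 4 (beyond the scatter). The estimate for compound 4 is 40%, with a range from 15% to 65%.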

Compound 4, a percentage reported as inhibition, in the whole organism at one dose (the size of the read-out at that dose, not a potency): 23.6%
Estimate against measurement, compound 4: 16.4 percentage points above; the measured number falls inside the stated range.
By their numbers in this assay, from the lowest: compounds 2 and 4 (each within the scatter of the next); then compound 1; then compound 3.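

In this assay, the swap on the carbonyl carbon gives a number 45.2 percentage points lower from compound 3 to compound 4 (beyond the scatter), even though piperazin-1-yl and morpholin-4-yl are both six-membered non-aromatic rings with the same number of heavy atoms. What differs is that morpholin-4-yl has an oxygen in place of the second ring nitrogen and has lost the hydrogen-bond donor, so ring size and heavy-atom count alone do not set the value at this position. The other two comparisons show how far compound 3 stands apart: a number 4.4 percentage points higher from compound 2 to compound 4 (within the scatter) means that morpholin-4-yl and pyrrolidin-1-yl cannot be told apart here, while a number 21.1 percentage points lower from compound 1 to compound 4 (beyond the scatter) leaves morpholin-4-yl under cyclohexylamino, and only piperazin-1-yl reaches the top value.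

No measurement shown accounts for the size of this drop. From the compounds shown here alone, it also remains open whether the ring nitrogen or its hydrogen is what matters: a 4-methylpiperazin-1-yl group, which keeps that nitrogen but carries a methyl group on it, and a piperidin-1-yl group, which has a carbon there instead, would help separate the two.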